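The compounds below may be only part of what the source reports. "The series", "measured", "known", "first", "only" and "open" are said of these compounds alone.

Measured in a functional assay on HepG2 cells (Homo sapiens) for inhibition, read by MTT assay, with a stated time of 72 h; on this read-out higher numbers stand for weaker inhibition and lower numbers for stronger inhibition:
Compound 1 `Cc1ccc(NC(=O)C2CCN(C/C=C/c3ccccc3)CC2)cc1`: 33900 nM
Compound 2 `COc1cccc(NC(=O)C2CCN(C/C=C/c3ccccc3)CC2)c1`: 78600 nM
Compound 3 `O=C(Nc1nccs1)C1CCN(C/C=C/c2ccccc2)CC1`: 22400 nM

Compound 3 sits at the low end of these numbers, an end it shares: the series shows a 1.5-fold lower number from compound 1 to compound 3 (0.18 log units; within the scatter), and also a 3.5-fold lower number from compound 2 to compound 3 (0.55 log units; beyond the scatter). Compound 4 `O=C(NCc1ccccc1)C1CCN(C/C=C/c2ccccc2)CC1` carries benzyl in place of 1,3-thiazol-2-yl on an amide-type nitrogen. Within the data shown here, those two steps bear on this change, since both concern the group on that nitrogen, though no measured compound carries benzyl. Both arrive at a lower number, so leaving 1,3-thiazol-2-yl is expected to give a somewhat higher number, probably not beyond the scatter. The expected step is a 1.7-fold higher number from compound 3 to compound 4 (0.23 log units; within the scatter). For compound 4 the estimate is 38000 nM, with an expected range from 17000 nM to 85000 nM.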

Compound 4, half-maximal inhibitory concentration: > 100000 nM
Compound 4: only a limit was reported (the forecaster's own chance of this, stated with the estimate: 10%); at least 2.6-fold (0.42 log units) between middle value and limit.
By their numbers in this assay, from the lowest: compounds 3 and 1 (each within the scatter of the next); then compound 2. At a limit, above all of these: compound 4.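

In this assay the entry for compound 4 is a limit, not a number: the limit of > 100000 nM in this assay, at which 1 of the 4 values shown sits. Among these compounds, with benzyl on the amide-type nitrogen, the series shows an at least 4.4-fold higher number from compound 3 to compound 4 (0.64 log units; beyond the scatter) and an at least 2.9-fold higher number from compound 1 to compound 4 (0.46 log units; beyond the scatter), so the group at this place can shift the number further than the earlier compounds showed. The remaining step, an at least 1.2-fold higher number from compound 2 to compound 4 (0.10 log units; that floor lies within the scatter), does not separate those two compounds.

On these data alone, how far the true number lies past the limit stays open, so these steps are known only as floors. Also open, as far as these compounds go, is how an unsubstituted phenyl, a pyridin-2-yl or a 2-phenylethyl group on that nitrogen would read.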